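From 3-carboxypyrrolidin-1-yl to 3-hydroxypyrrolidin-1-yl: working notes

The compounds below may be only part of what the source reports. "The series", "measured", "known", "first", "only" and "open" are said of these compounds alone.

Measured in a functional assay on B16-F10 cells (Mus musculus) for antiproliferative activity, read by CCK-8 assay, with a stated time of 48 h; a higher number here means a weaker inhibitor, a lower number a stronger inhibitor:
- compound 1 `COc1ccc(/C=C\c2cc(OC)c(OC)c(OC)c2)cc1OCc1ccc(CN2CCCCC2C(=O)O)cc1`: > 10000 nM (a limit)
- compound 2 `COc1ccc(/C=C\c2cc(OC)c(OC)c(OC)c2)cc1OCc1ccc(CN2CC[C@H](C(=O)O)C2)cc1`: 7000 nM

Within the data shown here, compound 2 carries the only true number so far. The result for compound 1 is a limit, (the limit of > 10000 nM in this assay, at which 1 of the 2 values shown sits).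

Compound 3 `COc1ccc(/C=C\c2cc(OC)c(OC)c(OC)c2)cc1OCc1ccc(CN2CC[C@@H](O)C2)cc1` differs from compound 2 in one place: 3-hydroxypyrrolidin-1-yl in place of 3-carboxypyrrolidin-1-yl on a saturated chain carbon bound to an aromatic carbon. Here 3-hydroxypyrrolidin-1-yl stands in place of 3-carboxypyrrolidin-1-yl, on a saturated chain carbon bound to an aromatic carbon.

Among the measured compounds shown here, the one measured step is an at least 1.4-fold lower number from compound 1 to compound 2 (0.15 log units; that floor lies within the scatter). For the measured compounds named here, it exchanges one carboxy-bearing group for another, and no measured step removes the carboxy group. It therefore sets the new step's size only loosely. A moderately lower number in this assay is expected, with wide uncertainty. The expected step is a 2.3-fold lower number from compound 2 to compound 3 (0.37 log units; beyond the scatter). Compound 3 is estimated at 3000 nM, with an expected range of 500 nM to 12000 nM.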

Compound 3, half-maximal inhibitory concentration: > 10000 nM
Compound 3 gave a limit, no number; the forecaster's own chance of this, stated with the estimate: 15%; middle value at least 3.3-fold (0.52 log units) from the limit.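

In this assay compound 3 gives > 10000 nM, which is a limit and not a number. The change to 3-hydroxypyrrolidin-1-yl is the first shown to remove the carboxy group, and it gives an at least 1.4-fold higher number from compound 2 to compound 3 (0.15 log units; that floor lies within the scatter), so no lower number appears at this place and compound 2 remains the only compound with a true number. The step between compound 1 and compound 3 cannot be read, and the series now sits mostly at the assay's ceiling: the limit of > 10000 nM in this assay, at which 2 of the 3 values shown sit.

As far as these compounds go, how far compound 1 and compound 3 lie past that limit stays open. Also open, from the compounds shown here alone, is whether 3-aminopyrrolidin-1-yl, or a longer chain ending in a carboxylic acid, on the saturated chain carbon bound to an aromatic carbon would change the reading in this assay.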